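This account rests on a few compounds, and the source may have more. Where it says the series, first, only, none or still open, it means among the compounds named here.

In an in vitro ADME assay on microsomes from liver (Homo sapiens) for pharmacokinetics (a lower number here means slower removal, a higher number faster removal of the compound), the measured compounds are known only through limits of the assay. Compound 1 `Cc1ccc(S(=O)(=O)N2C=CNC(=O)[C@H]2CC(=O)NC2CCNc3ccccc32)cc1` is reported as the limit < 50 mL.min-1.g-1. Compound 2 `Cc1ccc(S(=O)(=O)N2C=CNC(=O)[C@H]2CC(=O)NC2CCOCC2(C)C)cc1` is reported as the limit < 100 mL.min-1.g-1. Compound 3 `Cc1ccc(S(=O)(=O)N2C=CNC(=O)[C@H]2CC(=O)N[C@H]2CCN(C)CC2(C)C)cc1` is reported as the limit < 14 mL.min-1.g-1. Compound 4 `Cc1ccc(S(=O)(=O)N2C=CNC(=O)[C@H]2CC(=O)N[C@H]2CCN(C3CCCC3)CC2(C)C)cc1` differs from compound 3 at one place: cyclopentyl in place of methyl on an amine nitrogen in a ring. The measured changes, a step that the two limits leave unreadable from compound 1 to compound 3 and a step that the two limits leave unreadable from compound 2 to compound 3, as well as a step that the two limits leave unreadable from compound 1 to compound 2, give no size to carry over. The limit of compound 3 therefore remains the only anchor. A modest rise is expected, though no measured step sizes it, giving an estimated at least 1.2-fold higher number from compound 3 to compound 4 (0.10 log units; that floor lies within the scatter). For compound 4 the expected value is 18 mL.min-1.g-1, within an estimated range from 6 mL.min-1.g-1 to 55 mL.min-1.g-1.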

Compound 4, intrinsic clearance in microsomes: < 14 mL.min-1.g-1
Compound 4: only a limit was reported; the forecaster's own chance of this, stated with the estimate: 55%; at least 1.2-fold (0.10 log units) between middle value and limit.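

Compound 3 and compound 4 are each reported only as a limit, and the step from methyl to cyclopentyl cannot be read. The compounds shown leave open how quickly any of them is actually removed.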